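Replacing 4-methylpiperazin-1-yl with (dimethylamino)methyl on the side chain

The source may report more compounds than this note shows. Statements on the series, on what has been measured and on what is new or still open speak of the compounds shown alone.

Of the compounds shown here, three on a shared core have so far been measured in a toxicity assay on L02 cells (Homo sapiens) for cytotoxicity, read by MTT assay, with a stated time of 72 h (on this read-out lower numbers stand for stronger inhibition and higher numbers for weaker inhibition), for comparison. Compound 1 (`O=C1c2c[n+]([O-])c3ccccc3c2C(=O)c2c1c1ccccc1n2CCN1CCCC1`) gives 930 nM in this test, compound 2 (`CCCCN1CCN(CCCCn2c3c(c4ccccc42)C(=O)c2c[n+]([O-])c4ccccc4c2C3=O)CC1`) gives 5690 nM and compound 3 (`CN1CCN(CCCn2c3c(c4ccccc42)C(=O)c2c[n+]([O-])c4ccccc4c2C3=O)CC1`) gives 230 nM as the lowest number of the three. Compound 4 (`CN(C)CCCCn1c2c(c3ccccc31)C(=O)c1c[n+]([O-])c3ccccc3c1C2=O`) has not yet been measured. It differs from compound 3 in one place ((dimethylamino)methyl in place of 4-methylpiperazin-1-yl on a saturated chain carbon, three bonds along the chain from an aromatic nitrogen), so that a 3-(4-methylpiperazin-1-yl)propyl chain gives way to a 4-(dimethylamino)butyl chain.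

The measured steps all change this same side chain, and they differ in size and direction. The first is a 4.0-fold lower number from compound 1 to compound 3 (0.61 log units; beyond the scatter) and is modest. The second is a 6.1-fold higher number from compound 1 to compound 2 (0.79 log units; beyond the scatter) and is also modest. The third is a 25-fold lower number from compound 2 to compound 3 (1.39 log units; beyond the scatter) and is large. For the measured compounds named here, no measured compound ends its chain in an open-chain amine, so the data offer no direct precedent for this change. Every measured comparison with compound 3 nevertheless ends at a higher number, and a modest rise seems the most likely outcome. In this assay the expected change is therefore a 2.4-fold higher number from compound 3 to compound 4 (0.38 log units; beyond the scatter) and not a large one. For compound 4 the estimated value is 550 nM (expected range 150 nM to 2000 nM).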

Compound 4, half-maximal inhibitory concentration: 300 nM
Beside the measured number, compound 4's estimate is 1.8-fold (0.26 log units) above it; the measured number falls inside the stated range.
By their numbers in this assay, from the lowest: compounds 3 and 4 (each within the scatter of the next); then compound 1; then compound 2.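

In this assay, the change at this place, on a saturated chain carbon, three bonds along the chain from an aromatic nitrogen, gives a 1.3-fold higher number from compound 3 to compound 4 (0.12 log units; within the scatter). For the compounds shown here, the ring of 4-methylpiperazin-1-yl can therefore give way to the open-chain (dimethylamino)methyl with no difference that stands out from the scatter, something the earlier compounds, all ending in a ring, could not show. Compound 4 also shares the direction of compound 3 against the other two compounds, with a 3.1-fold lower number from compound 1 to compound 4 (0.49 log units; beyond the scatter) and a 19-fold lower number from compound 2 to compound 4 (1.28 log units; beyond the scatter), so a ring at the chain end is not needed for a number this low, while compound 2 shows that a piperazine ring alone does not ensure one. Nothing available accounts for these numbers.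

Since the chain's length and its end group change together from compound 3 to compound 4, the compounds shown leave open how a 3-(dimethylamino)propyl chain or a 4-(4-methylpiperazin-1-yl)butyl chain would read. Also open, from the compounds shown here alone, is how a morpholine or a primary amine at the chain end would compare in this assay.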